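Benzenesulfonyl series: expectation for the isopropyl analogue

This account rests on a few compounds, and the source may have more. Where it says the series, first, only, none or still open, it means among the compounds named here.

Three compounds of one core are measured. Compound 1 `CCC(C)C(C(=O)Nc1ccc(C(C)=O)cc1)N(C(=O)c1ccccc1)S(=O)(=O)c1ccc(C)cc1` gives 25.7% in a functional assay for inhibition, read by spectrophotometry, with a stated time of 20 min, tested at 2 mg/mL; a lower number here means a weaker effect, a higher number a stronger effect of the compound at the concentration tested. Compound 2 `CC(=O)c1ccc(NC(=O)C(C(C)C)N(C(=O)c2ccccc2)S(=O)(=O)c2ccc(C)cc2)cc1` differs from compound 1 by hydrogen in place of methyl on a saturated chain carbon, three bonds along the chain from an amide-type nitrogen and a carbonyl carbon and in this assay compound 2 gives 22.7%. The step of a number 3 percentage points lower from compound 1 to compound 2 (within the scatter) lies within the scatter, so no order between compound 1 and compound 2 is read from it. Compound 3 `CCC(C)C(C(=O)Nc1ccc(C(C)=O)cc1)N(C(=O)c1ccccc1)S(=O)(=O)c1ccccc1` differs from compound 1 by hydrogen in place of methyl on an aromatic carbon, and in this assay compound 3 gives 11.4%. The step of a number 14.3 percentage points lower from compound 1 to compound 3 (beyond the scatter) is beyond the scatter, as is the gap from compound 2 down to compound 3, so compound 3 stands lowest of the three measured compounds.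

Compound 4 `CC(=O)c1ccc(NC(=O)C(C(C)C)N(C(=O)c2ccccc2)S(=O)(=O)c2ccccc2)cc1` is not yet measured. It differs from compound 3 by hydrogen in place of methyl on a saturated chain carbon, three bonds along the chain from an amide-type nitrogen and a carbonyl carbon, which is the same change, in the same place, as that from compound 1 to compound 2; the two cores differ as set out above for compound 1 and compound 3. The change occurs twice in all among these compounds, once measured.

A step of a number 2.4 percentage points lower from compound 3 to compound 4 (within the scatter) is expected because a number 3 percentage points lower from compound 1 to compound 2 (within the scatter) stayed within the scatter, and the new pair sits on a core already at a lower level. The estimate rests on a single prior instance, so its range is kept wide. Compound 4 is expected to give 9% in this assay. The expected band for compound 4 runs from 0% to 20%.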

Compound 4, a percentage reported as inhibition, at one concentration (the size of the read-out at that concentration, not a potency): 41.3%
Estimate against measurement, compound 4: 32.3 percentage points below; the whole stated range lies below it.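

Working from sec-butyl to isopropyl on the core of compound 3 gives a number 29.9 percentage points higher from compound 3 to compound 4 (beyond the scatter) in this assay, so the change does not carry over from the core of compound 1, where its step stayed within the scatter: the same change on two cores in this assay, a number 3 percentage points lower (within the scatter) from compound 1 to compound 2 and a number 29.9 percentage points higher (beyond the scatter) from compound 3 to compound 4, 32.9 percentage points apart, beyond the scatter of two such steps

Hydrogen in place of methyl on an aromatic carbon likewise fails to carry over, now with a number 18.6 percentage points higher from compound 2 to compound 4 (beyond the scatter) against a step in the opposite direction on the sec-butyl core: the same change on two cores in this assay, a number 14.3 percentage points lower (beyond the scatter) from compound 1 to compound 3 and a number 18.6 percentage points higher (beyond the scatter) from compound 2 to compound 4, 32.9 percentage points apart, beyond the scatter of two such steps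

These two comparisons rest on the same four compounds and are one observation seen from two sides: in this set the two changes do not add, and the result on one core gives no safe estimate for the other, but nothing here shows why, and the read-out at a single concentration is not a potency.

Still open, going by these compounds, is whether this dependence on the partner group extends to other chains in place of sec-butyl and isopropyl, such as ethyl or a longer chain. Also open, on these data alone, is how a methoxy group or a chlorine in place of the methyl on the aromatic carbon would behave with each chain.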